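The source may hold more compounds than are shown below. What is called first, only, known or untested is meant among the compounds shown, and "the series" means these compounds.

In a functional assay on HeLa cells (Homo sapiens) for antiproliferative activity, read by MTT assay, with a stated time of 48 h (on this read-out higher numbers stand for weaker inhibition and lower numbers for stronger inhibition), compound 1 (`O=C(/C=C/c1ccccc1)Nc1cc2c(Nc3ccc(F)c(Cl)c3)ncnc2s1`) gives 2140 nM, compound 2 (`O=C(/C=C/c1ccccc1)Nc1cc2c(Nc3ccc(Cl)c(Cl)c3)ncnc2s1`) gives 430 nM and compound 3 (`O=C(/C=C/c1ccccc1)Nc1cc2c(Nc3cccc(Cl)c3F)ncnc2s1`) gives 34900 nM, the highest number of the three and so the weakest inhibition. Compound 4 (`C#Cc1cccc(Nc2ncnc3sc(NC(=O)/C=C/c4ccccc4)cc23)c1`) has 3-ethynylphenyl in place of 3-chloro-2-fluorophenyl on a nitrogen on an aromatic ring. Among the compounds with values here, no measured compound carries 3-ethynylphenyl. The nearest evidence is a 16-fold higher number from compound 1 to compound 3 (1.21 log units; beyond the scatter) and an 81-fold higher number from compound 2 to compound 3 (1.91 log units; beyond the scatter), both large, whereas a 5.0-fold lower number from compound 1 to compound 2 (0.70 log units; beyond the scatter) is only modest. Leaving 3-chloro-2-fluorophenyl is therefore expected to bring a large step to a lower number in this assay. The expected change is a 12-fold lower number from compound 3 to compound 4 (1.07 log units; beyond the scatter). For compound 4 the estimated value is 3000 nM, with an expected range of 600 nM to 15000 nM.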

Compound 4, half-maximal inhibitory concentration: 4640 nM
Compound 4: the middle estimate sits 1.5-fold (0.19 log units) below what was measured; measured number inside the range.
By their numbers in this assay, from the lowest: compound 2; then compound 1; then compound 4; then compound 3.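

In this assay, a halogen on the ring at this nitrogen on an aromatic ring is not required for activity: 3-ethynylphenyl in place of 3-chloro-2-fluorophenyl gives a 7.5-fold lower number from compound 3 to compound 4 (0.88 log units; beyond the scatter) in the series. It does not reach the level of the two halogenated groups, however, with a 2.2-fold higher number from compound 1 to compound 4 (0.34 log units; beyond the scatter) and an 11-fold higher number from compound 2 to compound 4 (1.03 log units; beyond the scatter) on this read-out. No measurement shown explains these steps.

From the compounds shown here alone, it remains open how an unsubstituted phenyl or a 3-ethylphenyl group would compare, which would test the contribution of the triple bond. A 3-aminophenyl group at this nitrogen is also untested in the compounds shown.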